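Three esters measured, a fourth awaited on the shared core

The compounds below may be only part of what the source reports. "The series", "measured", "known", "first", "only" and "open" are said of these compounds alone.

In a functional assay on HeLa cells (Homo sapiens) for cytotoxicity, read by MTT assay (on this read-out lower numbers stand for stronger inhibition and higher numbers for weaker inhibition), the three measured compounds gave the following numbers:
compound 1 `CCCCC(O)CC(=O)O[C@H](CC=C(C)C)C1=CC(=O)c2c(O)ccc(O)c2C1=O`: 72200 nM
compound 2 `CC(C)=CC[C@@H](OC(=O)C1CCOC1)C1=CC(=O)c2c(O)ccc(O)c2C1=O`: 73500 nM
compound 3 `CC(C)=CC[C@@H](OC(=O)CC(C)(O)C(C)C)C1=CC(=O)c2c(O)ccc(O)c2C1=O`: 27700 nM

Compound 3 stands lowest of the three, its neighbours both separated from it by steps beyond the scatter: a 2.6-fold lower number from compound 1 to compound 3 (0.42 log units; beyond the scatter) and a 2.7-fold lower number from compound 2 to compound 3 (0.42 log units; beyond the scatter). Compound 1 and compound 2, by contrast, sit within the scatter of each other, as a 1.0-fold higher number from compound 1 to compound 2 (0.01 log units; within the scatter) shows.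

The next compound, compound 4 `CC(C)=CC[C@@H](OC(=O)c1ccoc1)C1=CC(=O)c2c(O)ccc(O)c2C1=O`, differs from compound 3 in one place: furan-3-yl in place of 2-hydroxy-2,3-dimethylbutyl on a carbonyl carbon. The step that bears most directly on this is a 2.7-fold lower number from compound 2 to compound 3 (0.42 log units; beyond the scatter), since oxolan-3-yl and furan-3-yl are both five-membered rings with one oxygen carried on the carbonyl carbon, and compound 2 lies well above compound 3. The step of a 2.6-fold lower number from compound 1 to compound 3 (0.42 log units; beyond the scatter) points the same way: leaving the 2-hydroxy-2,3-dimethylbutyl group has so far meant a higher number. Compound 4 is therefore expected to give a higher number than compound 3, with a 2.0-fold higher number from compound 3 to compound 4 (0.30 log units; within the scatter) as the expected step. The estimate for compound 4 in this assay is 55000 nM, within a range from 20000 nM to 150000 nM.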

Compound 4, half-maximal inhibitory concentration: > 100000 nM
Compound 4: no number, only a limit (the forecaster's own chance of this, stated with the estimate: 10%); at least 1.8-fold (0.25 log units) between middle value and limit.
By their numbers in this assay, from the lowest: compound 3; then compounds 1 and 2 (each within the scatter of the next). At a limit, above all of these: compound 4.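

In this assay compound 4 reaches only a limit of the assay, not a number: the limit of > 100000 nM in this assay, at which 1 of the 4 values shown sits. Furan-3-yl on this carbonyl carbon does not keep the lower number of compound 3, an at least 3.6-fold higher number from compound 3 to compound 4 (0.55 log units; beyond the scatter), so the result extends the earlier finding that oxolan-3-yl in this place also gave a higher number, now to an aromatic five-membered ring. Against the other two esters the floors, an at least 1.3-fold higher number from compound 2 to compound 4 (0.13 log units; that floor lies within the scatter) and an at least 1.3-fold higher number from compound 1 to compound 4 (0.14 log units; that floor lies within the scatter), do not separate compound 4 from either of them.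

As far as these compounds go, it remains open how much of the lower number of compound 3 belongs to the branching of its chain, as compound 1 also carries a hydroxyl group. Also unsettled is what a branched chain without that hydroxyl, or an amine on the chain, would give in this assay.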